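From Fluoro to Chloro: What to Expect for Compound 3

The source may hold more compounds than are shown below. What is called first, only, known or untested is meant among the compounds shown, and "the series" means these compounds.

Of the compounds shown here, two have so far been measured in a functional assay, read by spectrophotometry, with a stated time of 15 min, tested at 80 ug/mL; a higher number here means a stronger effect of the compound at the concentration tested, a lower number a weaker effect. Compound 1 `COC(=O)c1cc(-c2csc(N/N=C/c3cccs3)n2)ccc1OCc1ccccc1` gives 87.6%. Compound 2 `Fc1ccc(-c2csc(N/N=C/c3ccc(Cl)cc3Cl)n2)cc1` gives 94%. That is the higher of the two numbers. The gap between compound 2 and compound 1 lies within the usual scatter of repeated measurements of this kind, and the two compounds cannot be told apart on this evidence.

Compound 3 `Clc1ccc(-c2csc(N/N=C/c3ccc(Cl)cc3Cl)n2)cc1` has not yet been measured in this assay. It differs from compound 2 in one place: chloro in place of fluoro on an aromatic carbon. Within the data shown here, no pair of measured compounds isolates the effect of this change, so the only footing is the two values given, which sit close together and both high.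

Compound 2 is already near the top of the scale, and the exchange of one halogen for another is a small alteration. The expected step from compound 2 to compound 3 in this assay is a number 2 percentage points lower from compound 2 to compound 3 (within the scatter), that is, no change beyond the scatter. Compound 3 is therefore estimated to give 92% in this assay, with a likely range from 82% to 98%.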

Compound 3, a percentage reported as inhibition, at one concentration (the size of the read-out at that concentration, not a potency): 83.1%
Estimate against measurement, compound 3: 8.9 percentage points above; the measured number falls inside the stated range.
By their numbers in this assay, from the lowest: compounds 3, 1 and 2 (each within the scatter of the next, the first and the last beyond it).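

Read in this assay, the change from 4-fluorophenyl to 4-chlorophenyl gives a number 10.9 percentage points lower from compound 2 to compound 3 (beyond the scatter) and is the first step here that isolates a single change. Compounds 1 and 2 differ in more than one place, so they could say nothing about this position alone, whereas compound 2 and compound 3 show that the read-out at this concentration depends on which halogen sits on the aromatic carbon para to a large group. The swap replaces one heavy atom with another, with no ring, hydrogen-bond donor, hydrogen-bond acceptor or net charge entering or leaving, and nothing available accounts for the modest loss.

With only fluoro and chloro shown at this position, one step cannot establish a trend, and it remains open whether a hydrogen, a bromo group, a methoxy group or an amine would match compound 2, compound 3 or neither. On these data alone, it also remains open whether the same exchange of fluoro for chloro would produce a similar step with a different group on the other side of the molecule.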